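Removing the benzyl methoxy: compound 2 to compound 3

The compounds below may be only part of what the source reports. "The series", "measured", "known", "first", "only" and "open" are said of these compounds alone.

Compound 2 `COc1cccc(CN2C(=O)CN(C(=O)c3cc4cc(OC)ccc4[nH]3)C[C@@H]2COCc2ccccc2)c1` carries a 3-methoxybenzyl group. In an ADME assay on Vero cells (Chlorocebus sabaeus) for cytotoxicity, with a stated time of 7 days (a higher number here means that more compound is tolerated, a lower number that less compound is tolerated), compound 2 gives only a limit, > 10000 nM, which is an assay ceiling and not a number. Compound 1 `COc1ccc2[nH]c(C(=O)N3CC(=O)N(Cc4ccccc4)[C@@H](CN4CCCCC4)C3)cc2c1` differs from compound 2 at more than one place; in this assay compound 1 is measured at 76900 nM. Compound 3 `COc1ccc2[nH]c(C(=O)N3CC(=O)N(Cc4ccccc4)[C@@H](COCc4ccccc4)C3)cc2c1` is not yet measured. It differs from compound 2 by hydrogen in place of methoxy on an aromatic carbon. Going by the values given here, no measured pair of this kind exists in the set, and the limit of > 10000 nM in this assay, at which 1 of the 2 values shown sits, leaves the numbers for compound 2 open-ended. An estimated step that the limit leaves unreadable from compound 2 to compound 3 is expected to lie within the scatter, with no direction assigned. Compound 3 is estimated at 50000 nM, within 15000 nM to 150000 nM, with a fair chance that this assay again returns only a limit.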

Compound 3, half-maximal cytotoxic concentration: > 30000 nM
Compound 3: a limit, no number; the forecaster's own chance of this, stated with the estimate: 50%; the middle value is on the limit's open side.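

In this assay, the steps to compound 3 from compound 2 and from compound 1 cannot be read, since compound 2 and compound 3 each return only a limit. The compounds shown leave open whether 3-methoxybenzyl to benzyl, or piperidin-1-yl to benzyloxy, changes the tolerated concentration at all.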